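Removing the Chloro Group from a Dimethoxystyryl Hydrazone

The compounds below may be only part of what the source reports. "The series", "measured", "known", "first", "only" and "open" are said of these compounds alone.

Compound 2 `COc1ccc(OC)c(/C=C/C(=O)N/N=C/c2ccc(Cl)cc2)c1` was tested in a functional assay on SK-MEL-28 cells (Homo sapiens) for antiproliferative activity, read by sulforhodamine B assay, with a stated time of 48 h; on this read-out lower numbers stand for stronger inhibition of growth and higher numbers for weaker inhibition of growth. In this assay compound 2 gives only a limit, > 100000 nM, and not a number. Compound 1 `COc1ccc(OC)c(/C=C/c2nnc(Nc3ccc(Cl)cc3)o2)c1`, which shares the dimethoxystyryl part, likewise gives only a limit in this assay, > 100000 nM. Both values sit at the same boundary, as the limit of > 100000 nM in this assay, at which 2 of the 2 values shown sit, records, so compound 2 stands level with compound 1 and no order between them can be drawn. The next compound, compound 3 `COc1ccc(OC)c(/C=C/C(=O)N/N=C/c2ccccc2)c1`, differs from compound 2 by hydrogen in place of chloro on an aromatic carbon. Within the data shown here, no measured step between these two exists, and because compound 2 sits at the limit with > 100000 nM, no movement beyond the scatter is expected in this assay. For compound 3 the estimate is 100000 nM, with a range from 30000 nM to 300000 nM. The expected step is a number no higher from compound 2 to compound 3 (the limit leaves the size open), none beyond the scatter.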

Compound 3, concentration for total growth inhibition: > 100000 nM
Compound 3: no number, only a limit; the forecaster's own chance of this, stated with the estimate: 80%; the middle value lies on the limit itself.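

Compound 3 gives the limit > 100000 nM in this assay and no number. Compound 2 also gives only a limit there, and no step can be read between compound 2 and compound 3. The compounds shown leave open whether hydrogen in place of chloro changes growth inhibition at all.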